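Second Methyl on the Phenyl Ring of Compound 2

The compounds below may be only part of what the source reports. "The series", "measured", "known", "first", "only" and "open" are said of these compounds alone.

Measured so far:
Compound 1, `COc1cc2c(Oc3ccc(NC(=O)c4cn(-c5ccccc5F)nn4)cc3F)ccnc2cc1OCCCN1CCN(C)CC1`: 250 nM
Compound 2, `COc1cc2c(Oc3ccc(NC(=O)c4cn(-c5ccccc5C)nn4)cc3F)ccnc2cc1OCCCN1CCN(C)CC1`: 3100 nM

Both were tested in a functional assay on A549 cells (Homo sapiens) for cytotoxicity, read by MTT assay, with a stated time of 72 h; on this read-out lower numbers stand for stronger inhibition and higher numbers for weaker inhibition. Compound 2 stands at the highest of the two numbers; its nearest neighbour is compound 1, and the step of a 12-fold higher number from compound 1 to compound 2 (1.09 log units; beyond the scatter) was large and beyond the scatter.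

Compound 3, `COc1cc2c(Oc3ccc(NC(=O)c4cn(-c5c(C)cccc5C)nn4)cc3F)ccnc2cc1OCCCN1CCN(C)CC1`, carries one further change: methyl in place of hydrogen on an aromatic carbon. Among the compounds with values here, no measured pair shows the effect of this second methyl. Within the data shown here, the only guidance is the step from compound 1 to compound 2, where a methyl gave a markedly higher number, so a further methyl is expected to push the number higher still or leave it about unchanged, giving a 1.6-fold higher number from compound 2 to compound 3 (0.21 log units; within the scatter). Compound 3 is thus estimated at 5000 nM, with a range from 1500 nM to 20000 nM.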

Compound 3, half-maximal inhibitory concentration: 2180 nM
The estimate for compound 3 lay 2.3-fold (0.36 log units) above the measured number, and the stated range covers the measured number.
By their numbers in this assay, from the lowest: compound 1; then compounds 3 and 2 (each within the scatter of the next).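

In this assay the step to 2,6-dimethylphenyl gives a 1.4-fold lower number from compound 2 to compound 3 (0.15 log units; within the scatter) and so shows that this second methyl, ortho to a large group, makes no readable difference. Compound 3 stays apart from the fluoro compound, with an 8.7-fold higher number from compound 1 to compound 3 (0.94 log units; beyond the scatter) as the step, so a second methyl does not close that gap. Nothing at hand gives a reason for either step.

Still open, on these data alone, is where the plain phenyl ring would stand on this read-out. The same goes for a 2-chlorophenyl or 2-methoxyphenyl ring, which could show whether compound 1 is a special case.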